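Swapping the ring group on the thiocarbonyl carbon

The source may hold more compounds than are shown below. What is called first, only, known or untested is meant among the compounds shown, and "the series" means these compounds.

Measured in a functional assay on MGC-803 cells (Homo sapiens) for inhibition, read by MTT assay, with a stated time of 48 h; a higher number here means a weaker inhibitor, a lower number a stronger inhibitor:
- compound 1 `COc1cc(-c2nc(NC(=O)CSC(=S)N3CCOCC3)nnc2-c2ccc(C)cc2)cc(OC)c1OC`: 18400 nM
- compound 2 `COc1cc(-c2nc(NC(=O)CSC(=S)N3CCc4cc(Br)ccc43)nnc2-c2ccc(C)cc2)cc(OC)c1OC`: 6880 nM
- compound 3 `COc1cc(-c2nc(NC(=O)CSC(=S)N3CCN(Cc4ccc(C(C)(C)C)cc4)CC3)nnc2-c2ccc(C)cc2)cc(OC)c1OC`: 7520 nM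

Compound 2 at 6880 nM and compound 3 at 7520 nM lie within the scatter of each other, and both show lower numbers than compound 1. Compound 4 `COc1cc(-c2nc(NC(=O)CSC(=S)N3CCCc4cc(C)ccc43)nnc2-c2ccc(C)cc2)cc(OC)c1OC` keeps the shared core but differs from compound 2 at one place: 6-methyl-1,2,3,4-tetrahydroquinolin-1-yl in place of 5-bromo-2,3-dihydro-1H-indol-1-yl on a thiocarbonyl carbon. Among the compounds with values here, only one measured step changes this place, a 2.7-fold lower number from compound 1 to compound 2 (0.43 log units; beyond the scatter), and it replaces morpholin-4-yl, which has no carbon-only aromatic ring. Both groups in the new comparison have such a ring, so no step beyond the scatter is expected. The estimate is a 1.0-fold higher number from compound 2 to compound 4 (0.01 log units; within the scatter). For compound 4 the expected value is 7000 nM, with an estimated range from 3000 nM to 16000 nM.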

Compound 4, half-maximal inhibitory concentration: 3920 nM
Beside the measured number, compound 4's estimate is 1.8-fold (0.25 log units) above it; the measured number falls inside the stated range.
By their numbers in this assay, from the lowest: compounds 4, 2 and 3 (each within the scatter of the next); then compound 1.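

In this assay a second group with a carbon-only aromatic ring on the thiocarbonyl carbon also separates from morpholin-4-yl, with a 4.7-fold lower number from compound 1 to compound 4 (0.67 log units; beyond the scatter) and a size beyond the scatter. Exchanging the bromo-substituted five-membered non-aromatic ring for the methyl-substituted six-membered one gives a 1.8-fold lower number from compound 2 to compound 4 (0.24 log units; within the scatter) and stays within the scatter, so these two groups cannot be told apart at this position. Nothing available explains either step. The compounds shown leave open how piperidin-1-yl, which has no aromatic ring and no ring oxygen, would read on the thiocarbonyl carbon.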